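Swapping the aryl ether group in weak Jurkat inhibitors

This account rests on a few compounds, and the source may have more. Where it says the series, first, only, none or still open, it means among the compounds named here.

Compound 1 `CC(C)[C@H](NC(=O)COc1cccc2ccccc12)C(=O)N[C@@H](CC(=O)O)C(=O)COc1ccc(-c2ccccc2)cc1` carries a 4-phenylphenyl group on an oxygen on a saturated carbon, and in a functional assay on Jurkat cells (Homo sapiens) (on this read-out higher numbers stand for weaker inhibition and lower numbers for stronger inhibition), compound 1 gives 87900 nM. Compound 2 `CC(=O)Nc1cccc(OCC(=O)[C@H](CC(=O)O)NC(=O)[C@@H](NC(=O)COc2cccc3ccccc23)C(C)C)c1` differs only by a 3-acetamidophenyl group in place of 4-phenylphenyl. For compound 2 this assay reports only a limit, > 100000 nM, and not a number. Compound 2 thus stands at the limit of > 100000 nM in this assay, at which 1 of the 2 values shown sits. The step of an at least 1.1-fold higher number from compound 1 to compound 2 (0.05 log units; that floor lies within the scatter) is therefore a floor rather than a measured change.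

Compound 3 `CC(C)[C@H](NC(=O)COc1cccc2ccccc12)C(=O)N[C@@H](CC(=O)O)C(=O)COc1ccc(F)c(F)c1` takes the next step: 3,4-difluorophenyl in place of 3-acetamidophenyl on an oxygen on a saturated carbon. Among the measured compounds shown here, only the step from compound 1 to compound 2 bears on this change, since it also swaps the group on the same oxygen, and it shifted the number by at most the small amount just given. Two different groups at this position gave numbers in the same region, so no step beyond the scatter is expected in this assay, and the result may again be only a limit. Compound 3 is expected to come out near 110000 nM, between 35000 nM and 350000 nM. The step that the limit leaves unreadable from compound 2 to compound 3 is thus estimated to be small.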

Compound 3, half-maximal inhibitory concentration: > 100000 nM
Compound 3 gave a limit, no number; the forecaster's own chance of this, stated with the estimate: 55%; the middle value is on the limit's open side.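

The 3,4-difluorophenyl group of compound 3 has 8 heavy atoms and 0 hydrogen-bond donors, while the 3-acetamidophenyl group of compound 2 has 10 heavy atoms and 1 hydrogen-bond donor, yet for both compounds the assay reports only a limit, so the step between them cannot be read. Replacing 4-phenylphenyl with 3,4-difluorophenyl gives an at least 1.1-fold higher number from compound 1 to compound 3 (0.05 log units; that floor lies within the scatter), so this second replacement, like the first, shows no change beyond the scatter, though the true size of the change remains hidden. The limit now holds for more than one group on this oxygen: the limit of > 100000 nM in this assay, at which 2 of the 3 values shown sit.

Among the compounds shown here, compound 1, at 87900 nM, remains the only compound here with a real number, so the position has no measured trend that could be followed from one group to the next. As far as these compounds go, whether an amine or a carboxylic acid on the aromatic ring, or a longer chain between the oxygen and that ring, would bring the number clearly down in this assay remains open.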